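Benzyl substituent changes and cytotoxicity in one series

This account rests on a few compounds, and the source may have more. Where it says the series, first, only, none or still open, it means among the compounds named here.

Measured compounds:
Compound 1 `CCOC(=O)c1cnc(N2CCN(Cc3cccc(C(F)(F)F)c3)CC2)nc1Oc1c(C)cc(-c2ccc(C#N)cc2)cc1C` gives in an ADME assay on MT4 cells (Homo sapiens) for cytotoxicity, read by MTT assay, with a stated time of 4 days (on this read-out higher numbers stand for lower toxicity in this test and lower numbers for higher toxicity in this test), the limit > 125000 nM.
Compound 2 `CCOC(=O)c1cnc(N2CCN(Cc3ccccc3Br)CC2)nc1Oc1c(C)cc(-c2ccc(C#N)cc2)cc1C` gives in this assay the limit > 125000 nM.
Compound 3 `CCOC(=O)c1cnc(N2CCN(Cc3ccc([N+](=O)[O-])cc3)CC2)nc1Oc1c(C)cc(-c2ccc(C#N)cc2)cc1C` gives in this assay the limit > 125000 nM.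

Compound 3 stands where every measured value of the series stands: at a limit of this assay, not at a number. The three measured steps, a step that the two limits leave unreadable from compound 1 to compound 2, a step that the two limits leave unreadable from compound 1 to compound 3 and a step that the two limits leave unreadable from compound 2 to compound 3, all run between limits and their size cannot be read; the only fact they share is the limit of > 125000 nM in this assay, at which 3 of the 3 values shown sit.

Compound 4 `CCOC(=O)c1cnc(N2CCN(Cc3ccccc3[N+](=O)[O-])CC2)nc1Oc1c(C)cc(-c2ccc(C#N)cc2)cc1C` keeps the same atoms as compound 3 and differs only in that (2-nitrophenyl in place of 4-nitrophenyl on a saturated chain carbon bound to an amine nitrogen in a ring). Among the measured compounds shown here, no measured step separates two nitrophenyl placements, so the change is judged by analogy with the other benzyl variations, all of which stayed at the limit. The step of a number no higher from compound 3 to compound 4 (the limit leaves the size open) is therefore expected to show no change beyond the scatter. Compound 4 is estimated at 125000 nM in this assay, within 60000 nM to 250000 nM, and most probably reported again as a limit.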

Compound 4, half-maximal cytotoxic concentration: >= 78700 nM
Compound 4 was reported as a limit; the forecaster's own chance of this, stated with the estimate: 85%; the middle value lies beyond the limit too.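

Compound 4 is reported in this assay as a limit, >= 78700 nM. Its steps from compound 1, compound 2 and compound 3 all run between limits and cannot be read. The compounds shown leave open whether any benzyl change alters cytotoxicity in this series.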